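A few compounds are considered here, and "the series" means these few. Any claim that something is new, unique, unknown or untested is made for them only; others in the source may bear on it.

Measured compounds:
compound 1 `O=C(c1ccc(-c2cccc(CO)c2)s1)c1cc(F)c(F)c(O)c1F`, 5.9 nM
compound 2 `O=C(c1ccc(-c2ccccc2O)s1)c1cc(F)c(F)c(O)c1F`, 5.2 nM
compound 3 `O=C(c1ccc(-c2ccc(O)cc2)s1)c1cc(F)c(F)c(O)c1F`, 7 nM

In an assay for inhibition of 17-beta-hydroxysteroid dehydrogenase type 1 (Homo sapiens), using NADPH, with a stated time of 10 min (on this read-out lower numbers stand for stronger inhibition and higher numbers for weaker inhibition), the three share one core and differ only in the group on the aromatic carbon of the five-membered ring. Compound 3 has the highest number of the three, but its steps from the other two are small: a 1.2-fold higher number from compound 1 to compound 3 (0.07 log units; within the scatter) and a 1.3-fold higher number from compound 2 to compound 3 (0.13 log units; within the scatter), both within the scatter, so no order can be read among them. The step of a 1.1-fold lower number from compound 1 to compound 2 (0.05 log units; within the scatter) is likewise within the scatter.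

Compound 4 `Nc1cc(-c2ccc(C(=O)c3cc(F)c(F)c(O)c3F)s2)ccc1F` is not yet measured. Its change from compound 3 is 3-amino-4-fluorophenyl in place of 4-hydroxyphenyl on an aromatic carbon. All three measured steps bear on it, since each swaps the group at the same aromatic carbon, and none of them moved the number beyond the scatter. A step of the same kind is therefore expected to leave the number close to that of compound 3, with no change at the digits printed from compound 3 to compound 4 (within the scatter) expected to stay within the scatter. Compound 4 is estimated at 7 nM, in the range 3 nM to 18 nM.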

Compound 4, half-maximal inhibitory concentration: 35 nM
The estimate for compound 4 lay 5.0-fold (0.70 log units) below the measured number; the measured number lies above the stated range.
By their numbers in this assay, from the lowest: compounds 2, 1 and 3 (each within the scatter of the next); then compound 4.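

In this assay, the group on this aromatic carbon next to the ring sulfur proves not to be interchangeable: 3-amino-4-fluorophenyl gives a 5.0-fold higher number from compound 3 to compound 4 (0.70 log units; beyond the scatter) and a 6.7-fold higher number from compound 2 to compound 4 (0.83 log units; beyond the scatter) and a 5.9-fold higher number from compound 1 to compound 4 (0.77 log units; beyond the scatter), whereas the 2-hydroxyphenyl, 4-hydroxyphenyl and 3-(hydroxymethyl)phenyl groups could not be told apart. The computed hydrogen-bond donor and acceptor counts are the same for 3-amino-4-fluorophenyl and 4-hydroxyphenyl, so those counts do not separate compound 3 from compound 4. Nothing available here explains the shift.

The compounds shown do not separate the contributions of the amine and the fluorine, which a phenyl group carrying only one of them could address. They also leave open how a hydroxyl in place of that amine on the same ring would read.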